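The source may report more compounds than this note shows. Statements on the series, on what has been measured and on what is new or still open speak of the compounds shown alone.

Values so far in a physicochemical assay for solubility, read by spectrophotometry, in phosphate buffer, with a stated time of 2 h, at pH 7.4; on this read-out lower numbers stand for lower solubility and higher numbers for higher solubility
- compound 1 (`COc1cccc(CN2C(=O)CN(C(=O)c3cc4cc(OC)ccc4o3)C[C@@H]2CCc2ccccc2)c1`): 4900 nM
- compound 2 (`COc1ccc2[nH]c(C(=O)N3CC(=O)N(Cc4ccccc4)[C@@H](COc4ccccc4)C3)cc2c1`): 12200 nM

Compound 2 at 12200 nM holds the higher of the two numbers, and the gap to compound 1 lies beyond the usual scatter. Within the data shown here, these two compounds differ in more than one place, so their gap offers no measured step for the change considered here.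

Still unmeasured is compound 3 (`COc1ccc2[nH]c(C(=O)N3CC(=O)N(Cc4ccccc4)[C@@H](COCc4ccccc4)C3)cc2c1`), which differs from compound 2 in one place: benzyl in place of phenyl on an oxygen on a saturated carbon. The same difference reads phenoxymethyl to (benzyloxy)methyl.

Among the measured compounds shown here, no measured pair shows this change, so the expectation is loose: a small step downward in this assay that may not exceed the scatter. The estimated step is a 1.4-fold lower number from compound 2 to compound 3 (0.13 log units; within the scatter) and carries wide uncertainty. For compound 3 the expected value is 9000 nM within an estimated range (3500 nM to 20000 nM).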

Compound 3, solubility: 8800 nM
Compound 3: the middle estimate sits 1.0-fold (0.01 log units) above what was measured, and the stated range covers the measured number.
By their numbers in this assay, from the lowest: compounds 1, 3 and 2 (each within the scatter of the next, the first and the last beyond it).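

In this assay, benzyl in place of phenyl on an oxygen on a saturated carbon gives a 1.4-fold lower number from compound 2 to compound 3 (0.14 log units; within the scatter), so at this position the move from phenoxymethyl to (benzyloxy)methyl produces no reading beyond the scatter. Among these compounds, this is the first measured step at this position, and on this read-out it does not separate the two compounds; it covers only this one change on this one shared core. Nothing on hand gives a reason for the size of this step.

From the compounds shown here alone, it remains open whether a longer chain at the same oxygen, such as phenethyl, or an amine or a carboxylic acid on the benzyl ring, would give a step beyond the scatter in this assay. Among the compounds shown here, also open is which of the places that set compound 1 apart from the other two matter on this read-out, as compound 1 differs from each of them in more than one place and no single step links it to either.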